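Replacing the selenium group of compound 2 with amino

The compounds below may be only part of what the source reports. "The series", "measured", "known", "first", "only" and "open" are said of these compounds alone.

Measured so far in a functional assay on RKO cells (Homo sapiens) for inhibition, read by MTT assay, with a stated time of 48 h; on this read-out lower numbers stand for stronger inhibition and higher numbers for weaker inhibition:
compound 1 `COc1ccc(N(C)c2nc(C)nc3ccccc23)cc1OCCC[Se]C#N`: 799 nM
compound 2 `COc1ccc(N(C)c2nc(C)nc3ccccc23)cc1OCC[Se]C#N`: 27 nM

Compound 2 holds the lower of the two numbers, making it the stronger inhibitor of the pair. Compound 3 `COc1ccc(N(C)c2nc(C)nc3ccccc23)cc1OCCN` keeps the shared core but ends its chain differently: one nitrogen atom in place of a group of 3 heavy atoms (1 carbon, 1 nitrogen, 1 selenium; no ring), on a saturated chain carbon, two bonds along the chain from an oxygen on an aromatic ring. Within the data shown here, the only measured step that bears on this is a 30-fold lower number from compound 1 to compound 2 (1.47 log units; beyond the scatter). It is large, so this assay can respond sharply to changes in this part of the molecule. Both measured compounds contain selenium, however, so the effect of removing it remains unmeasured. A clear rise is therefore expected with wide uncertainty, and the estimated step is an 11-fold higher number from compound 2 to compound 3 (1.05 log units; beyond the scatter). The estimate for compound 3 is 300 nM, with an expected range of 30 nM to 3000 nM.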

Compound 3, half-maximal inhibitory concentration: 343 nM
Beside the measured number, compound 3's estimate is 1.1-fold (0.06 log units) below it; measured number inside the range.
By their numbers in this assay, from the lowest: compound 2; then compound 3; then compound 1.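

With amino at this position, this assay shows a 13-fold higher number from compound 2 to compound 3 (1.10 log units; beyond the scatter) and so a compound without selenium still gives a measurable number, although the selenium group of compound 2 gives the lower one. The step of a 2.3-fold lower number from compound 1 to compound 3 (0.37 log units; beyond the scatter) places compound 3 between the two selenium compounds, so the presence of selenium alone does not set the order. Nothing measured here explains these differences. Still open, going by these compounds, is how a dimethylamino group, a carboxylic acid or a longer chain ending in amino would compare with compound 3 at this place.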